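Swapping the bromophenyl amide for a methylphenyl amide

A few compounds are considered here, and "the series" means these few. Any claim that something is new, unique, unknown or untested is made for them only; others in the source may bear on it.

Compound 2 `Cc1nc2c(F)cc(-c3nc(Nc4ccc(NC(=O)C5(C(=O)Nc6ccc(Br)cc6)CC5)cc4)ncc3F)cc2n1C(C)C` carries a 4-bromophenyl on the amide-type nitrogen of its cyclopropane diamide. Within the data shown here, in a functional assay on T47D cells (Homo sapiens) for antiproliferative activity, read by CCK-8 assay, with a stated time of 72 h (on this read-out lower numbers stand for stronger inhibition and higher numbers for weaker inhibition), compound 2 gives 120 nM, the higher of the two numbers measured so far. Among the measured compounds shown here, its closest relative, compound 1 `Cc1nc2c(F)cc(-c3nc(Nc4ccc(NC(=O)C5(C(=O)Nc6ccc(F)cc6)CC5)cc4)ncc3F)cc2n1C(C)C`, differs only in having fluoro where compound 2 has bromo, and in this assay compound 1 gives 25.5 nM; the step of a 4.7-fold higher number from compound 1 to compound 2 (0.67 log units; beyond the scatter) is the only measured change that bears on this position. Compound 3 `Cc1cccc(NC(=O)C2(C(=O)Nc3ccc(Nc4ncc(F)c(-c5cc(F)c6nc(C)n(C(C)C)c6c5)n4)cc3)CC2)c1` is not yet measured; it replaces (3-methylphenyl in place of 4-bromophenyl on an amide-type nitrogen). Because the measured step of a 4.7-fold higher number from compound 1 to compound 2 (0.67 log units; beyond the scatter) shows that a change on this ring can move the number well beyond the scatter, a shift is plausible, but there is no measurement of a methyl group here, so the direction is uncertain. Compound 3 is expected to fall near 70 nM, within the range 20 nM to 250 nM, which amounts to an expected step of a 1.7-fold lower number from compound 2 to compound 3 (0.23 log units; within the scatter).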

Compound 3, half-maximal inhibitory concentration: 203 nM
Estimate against measurement, compound 3: 2.9-fold (0.46 log units) below; measured number inside the range.
By their numbers in this assay, from the lowest: compound 1; then compounds 2 and 3 (each within the scatter of the next).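

In this assay the move from 4-bromophenyl to 3-methylphenyl on the amide-type nitrogen gives a 1.7-fold higher number from compound 2 to compound 3 (0.23 log units; within the scatter) and so does not separate compound 2 and compound 3. The larger contrast is with the 4-fluorophenyl group: an 8.0-fold higher number from compound 1 to compound 3 (0.90 log units; beyond the scatter) is a step beyond the scatter, so two different replacements for that group now both give clearly higher numbers than compound 1. No measurement shown explains why this group matters here.

From the compounds shown here alone, it remains open whether the step to compound 3 comes from the change of substituent or from its place on the ring, as this swap alters both at once. A 3-fluorophenyl or a 4-methylphenyl group would pull these apart, and a plain phenyl group would show what the ring gives with no substituent.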